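Benzothiazole in Place of Imidazole on the Sulfur Linker

The source may report more compounds than this note shows. Statements on the series, on what has been measured and on what is new or still open speak of the compounds shown alone.

Going by the values given here, compound 1 `Nc1ccccc1NC(=O)c1ccc(CSc2ncc[nH]2)cc1` gives 5000 nM in a functional assay on HCT-116 cells (Homo sapiens) for cytotoxicity, read by MTT assay (a higher number here means a weaker inhibitor, a lower number a stronger inhibitor), the highest of the three numbers known so far. Compound 2 `Nc1ccccc1NC(=O)c1ccc(CNc2ncc(Br)s2)cc1` gives 400 nM in this assay, and compound 3 `Nc1ccccc1NC(=O)c1ccc(CNc2nc3ccc(Br)cc3s2)cc1` gives 400 nM. Among the compounds with values here, the one recorded step, a 13-fold lower number from compound 1 to compound 2 (1.10 log units; beyond the scatter), shows that exchanging the heterocycle at this position can move the number a long way. Compound 4 `Nc1ccccc1NC(=O)c1ccc(CSc2nc3ccccc3s2)cc1` differs from compound 1 in the same region: 1,3-benzothiazol-2-yl in place of 1H-imidazol-2-yl on a sulfur. Compound 3, which also carries 1,3-benzothiazol-2-yl, gives 400 nM, well under compound 1. Since the sulfur linker of compound 1 is kept, a smaller drop than that is expected for compound 4, estimated as a 6.3-fold lower number from compound 1 to compound 4 (0.80 log units; beyond the scatter). Compound 4 is thus estimated at 800 nM, within 250 nM to 3000 nM.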

Compound 4, half-maximal inhibitory concentration: 800 nM
Compound 4: the middle estimate sits on the measured number at the digits printed; the range from low to high includes it.
By their numbers in this assay, from the lowest: compounds 2, 3 and 4 (each within the scatter of the next); then compound 1.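

With the sulfur kept, the exchange of the heterocycle alone gives a 6.3-fold lower number from compound 1 to compound 4 (0.80 log units; beyond the scatter) in this assay, so the number at this position responds to the ring itself. In the earlier step, a 13-fold lower number from compound 1 to compound 2 (1.10 log units; beyond the scatter), the sulfur and the ring changed together, which left the share of each unresolved. No measurement at hand explains the step now seen. From the compounds shown here alone, it remains open whether 1,3-benzoxazol-2-yl, with oxygen in place of the ring sulfur, would behave like 1,3-benzothiazol-2-yl. A longer chain in place of the saturated chain carbon on the sulfur is equally untested in what is shown here.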